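Benzyl removal on two uracil analogues, all at the ceiling

The compounds below may be only part of what the source reports. "The series", "measured", "known", "first", "only" and "open" are said of these compounds alone.

The study compares four compounds in a functional assay on SW-620 cells (Homo sapiens) for antiproliferative activity, read by MTT assay, with a stated time of 72 h; a higher number here means a weaker inhibitor, a lower number a stronger inhibitor. Compound 1 `C[Si](C)(C)CCOCn1c(CC(O)COCc2ccccc2)cc(=O)[nH]c1=O` carries a benzyl group on an oxygen on a saturated carbon. In this assay compound 1 gives only a limit, > 100000 nM. Compound 2 `C[Si](C)(C)CCOCn1c(CC(O)CO)cc(=O)[nH]c1=O` is the product of the change (hydrogen in place of benzyl on an oxygen on a saturated carbon). In this assay compound 2 likewise reaches only a limit, > 100000 nM. The step that the two limits leave unreadable from compound 1 to compound 2 therefore cannot be read as a number. Compound 3 `COCn1c(CC(O)COCc2ccccc2)c(C)c(=O)[nH]c1=O` has a different core; the difference between its core and that of compound 1 is not broken down here. In this assay compound 3 again gives only a limit, > 100000 nM. Among the measured compounds shown here, the one piece of evidence on these steps is the limit of > 100000 nM in this assay, at which 3 of the 3 values shown sit, so no measured step is readable.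

Compound 4 `COCn1c(CC(O)CO)c(C)c(=O)[nH]c1=O`, not yet measured, arises from compound 3 by the change (hydrogen in place of benzyl on an oxygen on a saturated carbon). The place line of this change is the same word for word as that of the change from compound 1 to compound 2, so it is the same change, made this time on the core of compound 3. Given that the step from compound 1 to compound 2 stayed within the limit, the account expects the step that the limit leaves unreadable from compound 3 to compound 4 for compound 4 to leave it at the limit as well. Compound 4 is therefore estimated at 150000 nM in this assay, between 60000 nM and 400000 nM, most likely reported only as a limit.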

Compound 4, half-maximal inhibitory concentration: > 100000 nM
Compound 4: no number, only a limit; the forecaster's own chance of this, stated with the estimate: 85%; the middle value lies beyond the limit too.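

In this assay compound 4 gives only a limit, > 100000 nM. Among the compounds shown here, the step from compound 3 to compound 4 therefore cannot be read as a number, any more than the one from compound 1 to compound 2. The compounds shown leave open whether hydrogen in place of benzyl changes the activity on either core, since the only reading they share is this: the limit of > 100000 nM in this assay, at which 4 of the 4 values shown sit.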